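Adding Chlorine to the Fused Rings of Compound 3

The source may hold more compounds than are shown below. What is called first, only, known or untested is meant among the compounds shown, and "the series" means these compounds.

Of the compounds shown here, three have been measured in an assay on CHO cells for activation of soluble guanylate cyclase alpha1/beta1 complex (Homo sapiens), read by cGMP accumulation; a higher number here means that more compound is needed for the effect, a lower number that less compound is needed. Compound 1 `CCCc1nn(-c2nc(N)c3c(n2)NC(=O)C3(C)C)c2ccc(Cl)cc12` gives 546000 nM. Compound 2 `Nc1nc(-n2nc(Cc3ccccc3F)c3ccccc32)nc2c1CC(=O)N2` gives 160 nM in this assay. Compound 3 `COC(=O)N(C)c1c(N)nc(-n2nc(Cc3c(F)ccc(F)c3F)c3ccccc32)nc1N` gives 270 nM, the second highest of the three numbers: its gap to compound 2 lies within the scatter, while compound 1 lies far beyond it. Compound 4 `COC(=O)N(C)c1c(N)nc(-n2nc(Cc3c(F)ccc(F)c3F)c3cc(Cl)ccc32)nc1N` differs from compound 3 by chloro in place of hydrogen on an aromatic carbon. Going by the values given here, no measured pair differs by this change alone, and compound 1, which also carries a chloro, differs from compound 3 in several other places, so its number says nothing about the chlorine. Only a small step, if any, is expected: a 1.1-fold higher number from compound 3 to compound 4 (0.05 log units; within the scatter). Compound 4 is expected to give 300 nM, with a range from 100 nM to 900 nM.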

Compound 4, half-maximal effective concentration: 700 nM
Estimate against measurement, compound 4: 2.3-fold (0.37 log units) below, within the range that was stated.
By their numbers in this assay, from the lowest: compounds 2 and 3 (each within the scatter of the next); then compound 4; then compound 1.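

Chloro in place of hydrogen on this aromatic carbon, meta to a fused ring and para to a fused ring, gives a 2.6-fold higher number from compound 3 to compound 4 (0.41 log units; beyond the scatter), so more compound is needed for the effect once the chlorine is present. Going by these compounds alone, this is the first step here that changes a single place, and it shows that the position responds to this change, though only modestly. Nothing measured here explains the step.

From the compounds shown here alone, whether a methyl or a methoxy group on this same carbon would give a similar step remains open. So does whether chloro on another carbon of this ring would behave alike.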